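This account rests on a few compounds, and the source may have more. Where it says the series, first, only, none or still open, it means among the compounds named here.

Compound 1 `CCN1C(=O)CSC1c1cccc(C(=O)NCCCCc2ccccc2)c1` gives 40%.
Compound 2 `COc1cc(F)ccc1N1C(=O)CSC1c1cccc(C(=O)NCCCCc2ccccc2)c1` gives 63%.
Compound 3 `O=C(NCCCCc1ccccc1)c1cccc(C2SCC(=O)N2c2cccc(F)c2)c1` gives 63%.

All three numbers come from a functional assay on 143B cells (Homo sapiens) for inhibition, read by CCK-8 assay, with a stated time of 72 h, tested at 1 uM (on this read-out higher numbers stand for more inhibition at the one concentration tested (going by the name of the read-out) and lower numbers for less inhibition), and the three compounds share one core, differing only in the group on the amide-type nitrogen in the five-membered ring. Compound 3 stands level with compound 2, and together they give the highest of the three numbers; compound 1, which carries an ethyl there, sits lowest, as the step of a number 23 percentage points higher from compound 1 to compound 3 (beyond the scatter) shows.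

Compound 4 `COc1cccc(OC)c1N1C(=O)CSC1c1cccc(C(=O)NCCCCc2ccccc2)c1` is not yet measured. Its change from compound 3 is 2,6-dimethoxyphenyl in place of 3-fluorophenyl on an amide-type nitrogen in a ring.

Among the compounds with values here, two measured steps bear on this. Putting an aromatic ring in place of ethyl on that nitrogen raised the number in both cases: a number 23 percentage points higher from compound 1 to compound 2 (beyond the scatter) and a number 23 percentage points higher from compound 1 to compound 3 (beyond the scatter). Swapping one aromatic ring for another, however, gave no change at the digits printed from compound 2 to compound 3 (within the scatter). The change to compound 4 is again a swap of one aromatic ring for another, so the expectation is a step of a number 5 percentage points lower from compound 3 to compound 4 (within the scatter) that stays within the scatter, with no clear direction. On that basis compound 4 is estimated at 58%, with a range from 40% to 75%.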

Compound 4, a percentage reported as inhibition, at one concentration (the size of the read-out at that concentration, not a potency): 31%
Estimate against measurement, compound 4: 27 percentage points above, and the stated range ends above it.
By their numbers in this assay, from the lowest: compounds 4 and 1 (each within the scatter of the next); then compounds 2 and 3 (each within the scatter of the next).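

The earlier swap between two aromatic rings changed nothing, but this one shows that the choice of ring on this nitrogen does matter: in this assay, 2,6-dimethoxyphenyl gives a number 32 percentage points lower from compound 3 to compound 4 (beyond the scatter) and, against the other aromatic ring, a number 32 percentage points lower from compound 2 to compound 4 (beyond the scatter). An aromatic ring in this place therefore does not by itself bring the gain over ethyl seen with compound 2 and compound 3, since the comparison with the ethyl compound gives a number 9 percentage points lower from compound 1 to compound 4 (within the scatter). Nothing among the data shown explains why this particular ring behaves differently from the other two.

The compounds shown leave open whether the loss goes with having two methoxy groups on the ring or with the particular pattern of 2,6-dimethoxyphenyl, as compound 2 keeps its number while carrying one methoxy group together with a fluorine. A 2-methoxyphenyl or a 2,6-dimethylphenyl group on the same nitrogen would help to separate these readings, and a 4-aminophenyl group would show how an amine on this ring fares.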